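A few compounds are considered here, and "the series" means these few. Any claim that something is new, unique, unknown or untested is made for them only; others in the source may bear on it.

Of the compounds shown here, two have been measured in a functional assay for inhibition, with Rattus norvegicus as the target; a higher number here means a weaker inhibitor, a lower number a stronger inhibitor. Compound 1 (`CC(N/C(=C\[N+](=O)[O-])Nc1ccncc1)C(C)(C)C`) gives 1000 nM. Compound 2 (`CC(/N=C(/S)Nc1cccnc1)C(C)(C)C`) gives 50.1 nM, the lower of the two numbers, which makes it the stronger inhibitor of the pair, by a gap that lies beyond the scatter. Compound 3 (`CC(C)(C)C(CO)/N=C(/S)Nc1cccnc1`) has not yet been measured in this assay. It departs from compound 2 by one change: hydroxy in place of hydrogen on a saturated chain carbon, two bonds along the chain from a double-bonded nitrogen. In words, hydroxy takes the place of hydrogen on a saturated chain carbon, two bonds along the chain from a double-bonded nitrogen, so that methyl becomes hydroxymethyl. Among the measured compounds shown here, no measured pair shows this change or any other single change, so the expectation rests on the structural change alone and remains uncertain. A moderate move towards a higher number, and so a weaker inhibitor, is expected, although a step within the scatter cannot be ruled out. The expected size of the move is estimated as a 4.0-fold higher number from compound 2 to compound 3 (0.60 log units; beyond the scatter). For compound 3 the estimated value is 200 nM, with an expected range from 60 nM to 800 nM.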

Compound 3, half-maximal inhibitory concentration: 3160 nM
Compound 3: middle estimate off by 16-fold (1.20 log units), on the low side, and the stated range ends below it.
By their numbers in this assay, from the lowest: compound 2; then compound 1; then compound 3.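

In this assay, the saturated chain carbon two bonds along the chain from a double-bonded nitrogen proves highly sensitive to substitution: replacing hydrogen with hydroxy, which turns methyl into hydroxymethyl, gives a 63-fold higher number from compound 2 to compound 3 (1.80 log units; beyond the scatter) and so a much weaker inhibitor. The earlier compounds shown here differed in more than one place and could not isolate this position, whereas this pair shows that adding one heavy atom there is enough to produce a large loss of inhibition. Nothing available accounts for the size of this step, so its cause remains unknown.

Among the compounds shown here, with only this one pair, it remains open whether the loss is specific to the hydroxy or would also follow from other replacements at this place, such as aminomethyl, methoxymethyl or a longer chain such as ethyl. It is also unknown whether the same change would weaken inhibition to a similar extent on the core of compound 1, which carries the nitro-substituted group in place of the sulfur-bearing one.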